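The source may hold more compounds than are shown below. What is called first, only, known or untested is meant among the compounds shown, and "the series" means these compounds.

Going by the values given here, compound 1 `N=c1c2c(-c3ccccc3)cn(Cc3ccccc3)c2ncn1C1CCOCC1` is the one member of this set with a plain number: in an ADME assay for permeability, using PAMPA, with a stated time of 30 min, at pH 7.4 (on this read-out higher numbers stand for higher permeability and lower numbers for lower permeability), compound 1 gives 1730 10^-6 cm/s. Compound 2 `COc1ccc(-c2c(-c3ccc(OC)cc3)n(Cc3ccccc3)c3ncn(CCCO)c(=N)c23)cc1` is reported in this assay only as a limit, and for compound 2 that limit is > 1000 10^-6 cm/s. Compound 3 `N=c1c2c(-c3ccccc3)cn(Cc3ccccc3)c2ncn1CCO` has not yet been measured in this assay; it differs from compound 1 by 2-hydroxyethyl in place of oxan-4-yl on an aromatic nitrogen. Among the compounds with values here, no measured pair traces this change, so the size of the step can only be expected. Compound 3 is estimated at 1200 10^-6 cm/s, between 500 10^-6 cm/s and 2500 10^-6 cm/s. The expected step of a 1.4-fold lower number from compound 1 to compound 3 (0.16 log units; within the scatter) is small, likely within the scatter, and a limit such as the limit of > 1000 10^-6 cm/s in this assay, at which 1 of the 2 values shown sits, may again be all that is reported.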

Compound 3, apparent permeability: 1270 10^-6 cm/s
Compound 3: the middle estimate sits 1.1-fold (0.02 log units) below what was measured; low and high end bracket the measured number.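

In this assay, going by these compounds alone, placing 2-hydroxyethyl on the aromatic nitrogen in place of oxan-4-yl gives a 1.4-fold lower number from compound 1 to compound 3 (0.13 log units; within the scatter), the first step that can be read at this position. Here, a ring without a hydrogen-bond donor and an open chain with one give values that cannot be told apart. Compound 2 remains a limit, so no step can be read from it: the limit of > 1000 10^-6 cm/s in this assay, at which 1 of the 3 values shown sits.

The compounds shown leave open how an amine or a carboxylic acid at the end of the chain on this nitrogen would read in this assay.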